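This account rests on a few compounds, and the source may have more. Where it says the series, first, only, none or still open, it means among the compounds named here.

Of the compounds shown here, three built on one shared core have been measured in a functional assay on RPMI-8226 cells (Homo sapiens) for cytotoxicity, read by sulforhodamine B assay, with a stated time of 48 h, tested at 0.1 uM; on this read-out lower numbers stand for a stronger effect and higher numbers for a weaker effect at the one concentration tested. Compound 1 `COc1cc(-c2cc(/C=C/C(=O)c3ccc(N)cc3)[nH]n2)cc(OC)c1OC` gives 97%, compound 2 `COc1cc(-c2cc(/C=C/C(=O)c3ccc(Cl)c(Cl)c3)[nH]n2)cc(OC)c1OC` gives 95%, and compound 3 `COc1ccc(C(=O)/C=C/c2cc(-c3cc(OC)c(OC)c(OC)c3)n[nH]2)cc1OC` gives 79%. Compound 3 thus stands lowest of the three numbers, meaning it shows the strongest effect here, and its distance to each of the other two lies beyond the scatter of repeated measurements.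

The next step leads to compound 4 `COc1cc(C(=O)/C=C/c2cc(-c3cc(OC)c(OC)c(OC)c3)n[nH]2)cc(OC)c1OC`. The change is methoxy in place of hydrogen on an aromatic carbon, so the ring attached to the carbonyl carbon carries one methoxy group more than in compound 3.

Going by the values given here, no measured step exchanges a hydrogen for a methoxy on that ring. The measured steps that come closest all swap the whole ring on the carbonyl carbon: a number 2 percentage points lower from compound 1 to compound 2 (within the scatter), a number 18 percentage points lower from compound 1 to compound 3 (beyond the scatter) and a number 16 percentage points lower from compound 2 to compound 3 (beyond the scatter). Together they show that changes at this ring move the read-out by modest amounts at most, and that the richer methoxy pattern of compound 3 gave the lower number. Adding one more methoxy is a smaller change than any of those, so a step that is small, possibly within the scatter, and if anything downward seems the most reasonable expectation.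

Compound 4 is therefore expected to give about 72% in this assay, most likely between 55% and 90%, which corresponds to an expected step of a number 7 percentage points lower from compound 3 to compound 4 (within the scatter).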

Compound 4, a percentage reported as activity, at one concentration (the size of the read-out at that concentration, not a potency): 83%
For compound 4 the middle estimate is 11 percentage points below the measured one; the measured number falls inside the stated range.
By their numbers in this assay, from the lowest: compounds 3 and 4 (each within the scatter of the next); then compounds 2 and 1 (each within the scatter of the next).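

In this assay, methoxy in place of hydrogen on an aromatic carbon, ortho to a methoxy group and meta to a second one, gives a number 4 percentage points higher from compound 3 to compound 4 (within the scatter). The earlier steps shown here each exchanged the whole ring on the carbonyl carbon, whereas this step changes one position of that ring and shows that one more methoxy group there produces no difference that can be told apart from the scatter, so the read-out does not follow the simple count of methoxy groups across this pair. No measurement is available that bears on why this step is so small.

The compounds shown leave open whether a different group at this position, such as a hydroxyl, an ethoxy group or a carboxylic acid, would move the number beyond the scatter, or whether removing a methoxy group from elsewhere on this ring would do so. They also leave open whether compound 3 and compound 4 would stay this close at concentrations other than the one tested, since a single concentration gives the size of an effect and not a potency.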